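Swapping cyclopropyl for benzyl on the amine of compound 2

The source may report more compounds than this note shows. Statements on the series, on what has been measured and on what is new or still open speak of the compounds shown alone.

Measured so far in an assay on cells with melanin-concentrating hormone receptor 1 (Homo sapiens) as the target, read by radioligand binding; on this read-out higher numbers stand for weaker inhibition and lower numbers for stronger inhibition:
compound 1, `CC(CNCC1CC1)Oc1cccc2ccc(N)nc12`, gives 80 nM
compound 2, `CC(CNC1CC1)Oc1cccc2ccc(N)nc12`, gives 50 nM
compound 3, `CC(CN1CCCC1)Oc1cccc2ccc(N)nc12`, gives 70 nM

All three share the same core and differ only in the group attached to the amine nitrogen. Compound 2 carries the lowest of the three numbers shown, yet its gaps to the others are small: a 1.6-fold lower number from compound 1 to compound 2 (0.20 log units; within the scatter) and a 1.4-fold higher number from compound 2 to compound 3 (0.15 log units; within the scatter) both fall within the scatter, as does a 1.1-fold lower number from compound 1 to compound 3 (0.06 log units; within the scatter). On these data the three amine groups cannot be told apart.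

Compound 4, `CC(CNCc1ccccc1)Oc1cccc2ccc(N)nc12`, has not been measured. It differs from compound 2 in one place: benzyl in place of cyclopropyl on an amine nitrogen. Among the measured compounds shown here, the one measured step at the same amine nitrogen, a 1.6-fold lower number from compound 1 to compound 2 (0.20 log units; within the scatter), exchanged two small ring-bearing groups and stayed within the scatter; the two steps to the pyrrolidine ring also stayed within the scatter. None of them brings in an aromatic group, so there is no direct guide for benzyl. Every change at this position has so far left this assay essentially unmoved. Compound 4 is therefore expected to land near compound 2. For compound 4 the expected step is a 1.2-fold higher number from compound 2 to compound 4 (0.08 log units; within the scatter). Compound 4 is estimated at 60 nM, with a range from 20 nM to 200 nM.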

Compound 4, half-maximal inhibitory concentration: 100 nM
For compound 4 the middle estimate is 1.7-fold (0.22 log units) below the measured one; measured number inside the range.
By their numbers in this assay, from the lowest: compounds 2, 3, 1 and 4 (each within the scatter of the next).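

In this assay, the first aromatic ring at this position gives a 2.0-fold higher number from compound 2 to compound 4 (0.30 log units; within the scatter), which is within the scatter, so benzyl, with 7 heavy atoms against 3 for cyclopropyl, cannot be told apart from the smaller ring on this amine nitrogen. Placing phenyl instead of cyclopropyl on a saturated chain carbon bound to an amine nitrogen gives a 1.3-fold higher number from compound 1 to compound 4 (0.10 log units; within the scatter), also within the scatter, so the aromatic ring and the three-membered ring read alike here as well. Nothing available explains why these groups give such similar numbers.

On these data alone, all the groups compared at this amine nitrogen are built of carbon alone, so it remains open whether a group carrying a hydroxyl, a carboxylic acid or a second amine would stay in the same range. Also unanswered is how a longer chain such as phenethyl, or a chlorine or methoxy group on the benzyl ring, would read in this assay, since the four compounds shown stop at unsubstituted benzyl.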